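Cyclohexyl for 4-fluorophenyl on the ring amide nitrogen

This account rests on a few compounds, and the source may have more. Where it says the series, first, only, none or still open, it means among the compounds named here.

Measured compounds:
Compound 1 `O=C1COc2ccc(-c3cccc(NS(=O)(=O)c4ccc(F)cc4)c3)cc2N1c1ccccc1`; in a functional assay on A549 cells (Homo sapiens) for antiproliferative activity, read by MTT assay, with a stated time of 72 h (on this read-out higher numbers stand for weaker inhibition and lower numbers for stronger inhibition), compound 1 gives > 40000 nM, which is a limit of the assay.
Compound 2 `COc1cccc(N2C(=O)COc3ccc(-c4cnc5ccccc5c4)cc32)c1`; in this assay compound 2 gives > 40000 nM, which is a limit of the assay.
Compound 3 `O=C1COc2ccc(-c3cccc(NS(=O)(=O)c4ccc(F)cc4)c3)cc2N1c1ccc(F)cc1`; in this assay compound 3 gives > 40000 nM, which is a limit of the assay.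

Compound 3 stands at a limit and not at a number, as do the other two values shown. For the measured compounds named here, the only step between measured compounds that differ in one place, a step that the two limits leave unreadable from compound 1 to compound 3, cannot be read in size, since both ends sit at the limit; this is the situation described by the limit of > 40000 nM in this assay, at which 3 of the 3 values shown sit.

Compound 4 `O=C1COc2ccc(-c3cccc(NS(=O)(=O)c4ccc(F)cc4)c3)cc2N1C1CCCCC1` differs from compound 3 by cyclohexyl in place of 4-fluorophenyl on an amide-type nitrogen in a ring.

Going by the values given here, no measured step bears on this change, and no measured step has a readable size. There is therefore no basis for expecting a step beyond the scatter in either direction in this assay; the expectation is that the change from compound 3 to compound 4, a step that the limit leaves unreadable from compound 3 to compound 4, does not bring compound 4 off the limit. Compound 4 is estimated at 60000 nM, with a range from 20000 nM to 200000 nM.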

Compound 4, half-maximal inhibitory concentration: 14500 nM
Compound 4: the middle estimate sits 4.1-fold (0.62 log units) above what was measured; measured number below the stated range.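

In this assay the ring amide nitrogen is the one position shown where a change brings a compound off the limit: cyclohexyl in place of 4-fluorophenyl gives an at least 2.7-fold lower number from compound 3 to compound 4 (0.44 log units; beyond the scatter) and cyclohexyl in place of phenyl gives an at least 2.7-fold lower number from compound 1 to compound 4 (0.44 log units; beyond the scatter) on the same core. On this core, then, a six-membered non-aromatic carbon ring on this nitrogen gives a readable number, whereas the two aromatic rings carried there by compound 1 and compound 3 do not. Both steps give only a lower bound on their size, and the step between compound 1 and compound 3 cannot be read, because the compounds at the far end of these comparisons sit at a limit: the limit of > 40000 nM in this assay, at which 3 of the 4 values shown sit.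

From the compounds shown here alone, it remains open whether the readable number depends on the cyclohexyl ring itself or would also appear with other groups on this nitrogen, such as cyclopentyl, an isopropyl group, a longer alkyl chain or a cyclohexyl ring carrying an amine. The compounds shown also leave open whether the sulfonamide side of the core contributes to the value of compound 4, since no change at that side is paired with cyclohexyl on the nitrogen.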